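The source may hold more compounds than are shown below. What is called first, only, known or untested is meant among the compounds shown, and "the series" means these compounds.

Measured compounds:
compound 1 `CNCC(=O)Nc1ccc(-c2nc(C(C)(C)S(C)(=O)=O)cc([C@]34CCOC[C@H]3C4)n2)cc1`, 217 ug/mL
compound 2 `CCNC(=O)Nc1ccc(-c2nc(C(C)(C)S(C)(=O)=O)cc([C@@]34CCOC[C@@H]3C4)n2)cc1`, 78 ug/mL
compound 3 `CCNC(=O)Nc1ccc(-c2nc(C(C)(C)S(C)(=O)=O)cc([C@]34CCOC[C@H]3C4)n2)cc1`, 74 ug/mL

The three compounds were measured in a physicochemical assay for solubility, in phosphate buffer, measured as kinetic solubility, with a stated time of 1 h, at pH 7.4; on this read-out lower numbers stand for lower solubility and higher numbers for higher solubility. Compound 1 gives 217 ug/mL, compound 2 gives 78 ug/mL and compound 3 gives 74 ug/mL. Compounds 2 and 3 are mirror images: the two compounds have the same atoms and bonds and differ only in configuration as drawn: 2 of 2 stereo elements differ (all stereocentres are inverted: mirror images); a stereocentre at a saturated ring carbon is drawn R in compound 3 and S in compound 2; a stereocentre at a saturated ring carbon is drawn S in compound 3 and R in compound 2. The step of a 1.1-fold lower number from compound 2 to compound 3 (0.02 log units; within the scatter) lies within the scatter, and the only thing that separates them is the fact that compounds 2 and 3 differ only in the configuration as drawn.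

The change from compound 3 to compound 1 is (methylamino)methyl in place of ethylamino on a carbonyl carbon. It gave the step of a 2.9-fold higher number from compound 3 to compound 1 (0.47 log units; beyond the scatter).

Compound 4 `CNCC(=O)Nc1ccc(-c2nc(C(C)(C)S(C)(=O)=O)cc([C@@]34CCOC[C@@H]3C4)n2)cc1` has not yet been measured in this assay. It arises from compound 2 by (methylamino)methyl in place of ethylamino on a carbonyl carbon. The place line reads the same as for the step from compound 3 to compound 1, so this is the same change, made on the mirror-image core.

Because compounds 2 and 3 stand within the scatter of each other in the step of a 1.1-fold lower number from compound 2 to compound 3 (0.02 log units; within the scatter), the step of a 2.8-fold higher number from compound 2 to compound 4 (0.45 log units; beyond the scatter) is expected to match the step of a 2.9-fold higher number from compound 3 to compound 1 (0.47 log units; beyond the scatter). Compound 4 is therefore estimated at 220 ug/mL, with a range from 120 ug/mL to 400 ug/mL.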

Compound 4, solubility: 257 ug/mL
The estimate for compound 4 lay 1.2-fold (0.07 log units) below the measured number; the range from low to high includes it.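

In this assay, putting (methylamino)methyl in place of ethylamino on a carbonyl carbon gave a 3.3-fold higher number from compound 2 to compound 4 (0.52 log units; beyond the scatter), in the same direction as a 2.9-fold higher number from compound 3 to compound 1 (0.47 log units; beyond the scatter) on the mirror-image core, and both steps lie beyond the scatter, so in this pair of compounds the change carried from one core to the other. Among the compounds shown here, the two products also stand within the scatter of each other, at a 1.2-fold higher number from compound 1 to compound 4 (0.07 log units; within the scatter), and only one thing separates them: the fact that compounds 1 and 4 differ only in the configuration as drawn This does not show why the number rises, nor whether the change would carry to a core that differs in its atoms rather than in its configuration as drawn, since the only two cores here are mirror images.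

The compounds shown leave open whether a longer chain such as propylamino, a dimethylamino group or a carboxylic acid on the same carbonyl carbon would give a similar step. They also leave open whether either step would hold on a core with different atoms.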